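The source may report more compounds than this note shows. Statements on the series, on what has been measured and on what is new or still open speak of the compounds shown alone.

Of the compounds shown here, two built on one shared core have so far been measured in a functional assay on DU-145 cells (Homo sapiens) for cytotoxicity, read by MTT assay, with a stated time of 48 h; a higher number here means a weaker inhibitor, a lower number a stronger inhibitor. Compound 1 `COc1ccc2c(C3(c4c[nH]c5cc(OC)ccc45)C(=O)Nc4ccccc43)c[nH]c2c1` gives 1200 nM, the lowest of the two numbers. Among the measured compounds shown here, compound 2 `O=C1Nc2ccccc2C1(c1c[nH]c2ccc([N+](=O)[O-])cc12)c1c[nH]c2ccc([N+](=O)[O-])cc12` gives 8000 nM, a number that lies beyond the scatter above that of compound 1; compound 2 differs from compound 1 in more than one place, and no single step links the two. Compound 3 `COc1ccc2c(C3(c4c[nH]c5cc(OC)ccc45)C(=O)Nc4ccc(F)cc43)c[nH]c2c1` has not yet been measured. It differs from compound 1 only by fluoro in place of hydrogen on an aromatic carbon, with everything else kept in place. For the measured compounds named here, no measured pair shows what such a swap does here; the expectation rests only on the nature of the change itself, a single fluorine entering with no ring, no hydrogen-bond donor and no hydrogen-bond acceptor. For compound 3 the step of a 1.1-fold lower number from compound 1 to compound 3 (0.04 log units; within the scatter) is expected to stay within the usual scatter, in either direction. Compound 3 is therefore estimated at 1100 nM, with a likely range from 450 nM to 3000 nM.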

Compound 3, half-maximal inhibitory concentration: 13100 nM
Compound 3: middle estimate off by 12-fold (1.08 log units), on the low side, and the stated range ends below it.
By their numbers in this assay, from the lowest: compound 1; then compounds 2 and 3 (each within the scatter of the next).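

Fluoro in place of hydrogen on an aromatic carbon of the shared core gives an 11-fold higher number from compound 1 to compound 3 (1.04 log units; beyond the scatter) in this assay, with everything else kept in place. Among the compounds shown here, this is the first pair here that differs in one place, and it shows that this position is not indifferent: even a small swap on this six-membered aromatic ring can weaken the compound well beyond the scatter. No measurement shown here accounts for the loss.

As far as these compounds go, it remains open whether the loss is specific to fluoro or would follow any group at this carbon; a chloro, a methoxy or an amine in the same place could help to tell these apart. From the compounds shown here alone, it also remains open whether fluoro on another carbon of this ring would give a similar step.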